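Chloro to methyl on the aryl ring: compound 4

This account rests on a few compounds, and the source may have more. Where it says the series, first, only, none or still open, it means among the compounds named here.

Compound 1, `CCC(=O)N1N=C(c2ccc(F)cc2)CC1c1ccc(C)cc1`, gives 151 nM in an assay on isolated protein for inhibition of Amine oxidase [flavin-containing] B (Bos taurus); a lower number here means a stronger inhibitor, a higher number a weaker inhibitor.
Compound 2, `CCC(=O)N1N=C(c2ccc(OC)cc2)CC1c1ccccc1`, gives 25100 nM.
Compound 3, `CCC(=O)N1N=C(c2ccc(OC)cc2)CC1c1ccc(Cl)cc1`, gives 851 nM.

Compound 3 stands second highest of these three numbers; compound 1 is its nearest neighbour and compound 2 the furthest. Going by the values given here, the only single change measured so far is a 29-fold lower number from compound 2 to compound 3 (1.47 log units; beyond the scatter), showing that a group at this aromatic carbon changes the number greatly. Compound 4, `CCC(=O)N1N=C(c2ccc(OC)cc2)CC1c1ccc(C)cc1`, differs from compound 3 by methyl in place of chloro on an aromatic carbon. Compound 1 also carries methyl on the corresponding ring, but with a different partner ring, so its value is only a loose hint. Among the compounds with values here, no measured step follows chloro to methyl directly, so the change is expected to be modest, a 1.2-fold higher number from compound 3 to compound 4 (0.07 log units; within the scatter). Compound 4 is estimated at 1000 nM, likely between 300 nM and 3500 nM.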

Compound 4, half-maximal inhibitory concentration: 10000 nM
Beside the measured number, compound 4's estimate is 10-fold (1.00 log units) below it; the whole stated range lies below it.
By their numbers in this assay, from the lowest: compound 1; then compound 3; then compound 4; then compound 2.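

In this assay the identity of the group on this ring carbon matters, not just its presence: a 12-fold higher number from compound 3 to compound 4 (1.07 log units; beyond the scatter) marks a large weakening. Methyl gives back only a small part of what chloro gained, as a 2.5-fold lower number from compound 2 to compound 4 (0.40 log units; beyond the scatter) is only a modest improvement. With 4-methylphenyl held fixed, a 66-fold higher number from compound 1 to compound 4 (1.82 log units; beyond the scatter) shows that the group on the other aromatic ring also has a large effect.

No evidence at hand explains why chloro and methyl differ so widely. Still open, as far as these compounds go, is how bromo, trifluoromethyl or an amine would behave at this carbon.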